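This account rests on a few compounds, and the source may have more. Where it says the series, first, only, none or still open, it means among the compounds named here.

Measured so far:
compound 1 `CC(C)c1c(O[C@H]2CCCC[C@@H]2C)cc(CCc2ccccc2)[nH]c1=O` — > 300000 nM
compound 2 `CC(C)c1c(Cc2ccccc2)n(COCc2ccccc2)c(=O)[nH]c1=O` — 84600 nM
compound 3 `CC1CCCCC1Oc1cc(CCc2ccccc2)[nH]c(=O)c1I` — > 300000 nM

In an ADME assay on MT4 cells (Homo sapiens) for cytotoxicity, read by XTT assay, with a stated time of 3 days (a lower number here means that less compound is tolerated, a higher number that more compound is tolerated), compound 1 gives only a limit, > 300000 nM. Compound 2 gives a number in this assay, 84600 nM. Compound 3 likewise gives only a limit in this assay, > 300000 nM. On the numbers shown, compound 3 stands at the limit of > 300000 nM in this assay, at which 2 of the 3 values shown sit. For the measured compounds named here, no step between measured compounds is available in this assay.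

Compound 4 `CC1CCCCC1Oc1cc(CCc2ccccc2)[nH]c(=O)c1Br` differs from compound 3 by bromo in place of iodo on an aromatic carbon. Such a change is expected to move this assay little, nothing beyond the scatter, with a limit again the most likely outcome. Compound 4 is expected at 300000 nM, within 150000 nM to 600000 nM. That estimate means a number no higher from compound 3 to compound 4 (the limit leaves the size open).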

Compound 4, half-maximal cytotoxic concentration: 100000 nM
Compound 4: middle estimate off by 3.0-fold (0.48 log units), on the high side, and the stated range ends above it.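

In this assay, the halogen on this aromatic carbon matters: bromo in place of iodo gives an at least 3.0-fold lower number from compound 3 to compound 4 (0.47 log units; beyond the scatter). This is the first step shown at this position, and compound 4 gives a measured number on the shared core. Compound 3 gives only a limit, so the full size of the step remains unknown, and that limit recurs in this set: the limit of > 300000 nM in this assay, at which 2 of the 4 values shown sit.

As far as these compounds go, whether chloro, fluoro or an amine at this position would give a lower or higher number stays open. The compounds shown also leave open whether the step holds on other cores.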